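A few compounds are considered here, and "the series" means these few. Any claim that something is new, unique, unknown or untested is made for them only; others in the source may bear on it.

In an ADME assay on MT4 cells (Homo sapiens) for cytotoxicity, read by MTT assay, with a stated time of 5 days (a lower number here means that less compound is tolerated, a higher number that more compound is tolerated), compound 1 `Cc1cc(C)cc(S(=O)(=O)c2c(C(N)=O)[nH]c3ccc(Cl)cc23)c1` gives 13000 nM and compound 3 `Cc1cc(C)cc(S(=O)(=O)c2c(C(=O)N[C@H]3CCN(S(C)(=O)=O)C3)[nH]c3ccc(Cl)cc23)c1` gives 29900 nM, the higher of these two numbers. This is a 2.3-fold higher number from compound 1 to compound 3 (0.36 log units; beyond the scatter). Compound 2 `Cc1cc(C)cc(S(=O)(=O)c2c(C(=O)N[C@H]3CCN(Cc4ccccc4C#N)C3)[nH]c3ccc(Cl)cc23)c1` reads > 228000 nM, which is a limit of the assay.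

Compound 4 `Cc1cc(C)cc(S(=O)(=O)c2c(C(=O)N[C@H]3CCN(CC(N)=O)C3)[nH]c3ccc(Cl)cc23)c1` differs from compound 3 on an amine nitrogen in a ring: carbamoylmethyl in place of methylsulfonyl on an amine nitrogen in a ring. The measured step most relevant to this change falls at the same place, with methylsulfonyl in place of 2-cyanobenzyl: an at least 7.6-fold lower number from compound 2 to compound 3 (0.88 log units; beyond the scatter). Replacing methylsulfonyl may therefore recover part of that step in this assay. The expected step, modest and upward, is a 2.3-fold higher number from compound 3 to compound 4 (0.37 log units; beyond the scatter). For compound 4, the estimated value is 70000 nM, with an expected range of 22000 nM to 220000 nM.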

Compound 4, half-maximal cytotoxic concentration: 28100 nM
For compound 4 the middle estimate is 2.5-fold (0.40 log units) above the measured one, within the range that was stated.
By their numbers in this assay, from the lowest: compound 1; then compounds 4 and 3 (each within the scatter of the next). At a limit, above all of these: compound 2.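

In this assay, carbamoylmethyl in place of methylsulfonyl on the amine nitrogen in the ring leaves no readable difference: a 1.1-fold lower number from compound 3 to compound 4 (0.03 log units; within the scatter). The rise over compound 1 seen with methylsulfonyl also appears with carbamoylmethyl: a 2.2-fold higher number from compound 1 to compound 4 (0.33 log units; beyond the scatter). Compound 2 stands at a limit of the assay, and its gap to the carbamoylmethyl compound is only a bound, an at least 8.1-fold lower number from compound 2 to compound 4 (0.90 log units; beyond the scatter): the limit of > 228000 nM in this assay, at which 1 of the 4 values shown sits.

Open, on these data alone, is whether a plain benzyl without the nitrile reads with compound 2 or with compounds 3 and 4. Also open, as far as these compounds go, is where a carboxylic acid on the same nitrogen would fall.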